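A few compounds are considered here, and "the series" means these few. Any claim that something is new, unique, unknown or untested is made for them only; others in the source may bear on it.

Working notes on the series. Compound 1 `N#Cc1ccc(OCc2cn(C(c3ccc(C#N)cc3)c3ccc(C#N)cc3)nn2)cc1` gives in an assay on isolated protein for inhibition of Aromatase (Homo sapiens), read by fluorescence and colorimetric assay, with a stated time of 30 min (a higher number here means a weaker inhibitor, a lower number a stronger inhibitor), a value of 4640 nM. Compound 2 `Cc1ccc(OCc2cn(C(c3ccc(C#N)cc3)c3ccc(C#N)cc3)nn2)cc1` differs from compound 1 by methyl in place of cyano on an aromatic carbon, and in this assay compound 2 gives 11000 nM; the step is a 2.4-fold higher number from compound 1 to compound 2 (0.37 log units; beyond the scatter). Compound 3 `N#Cc1ccc(OCc2cn(Cc3ccccc3)nn2)cc1` carries a different core; how the two cores differ is not broken down here. In this assay compound 3 gives 1360 nM, the lowest of the three measured numbers. Compound 4 `Cc1ccc(OCc2cn(Cc3ccccc3)nn2)cc1` is not yet measured; it differs from compound 3 by methyl in place of cyano on an aromatic carbon, the same change as that from compound 1 to compound 2, made at the same place. For the measured compounds named here, the expected step of a 2.4-fold higher number from compound 3 to compound 4 (0.38 log units; beyond the scatter) rests on the single measured instance, a 2.4-fold higher number from compound 1 to compound 2 (0.37 log units; beyond the scatter), applied to compound 3 at 1360 nM. Compound 4 is therefore expected to give about 3300 nM in this assay. Compound 4 is estimated to fall between 1700 nM and 6500 nM.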

Compound 4, half-maximal inhibitory concentration: 2270 nM
For compound 4 the middle estimate is 1.5-fold (0.16 log units) above the measured one, and the stated range covers the measured number.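

In this assay, methyl in place of cyano on an aromatic carbon gives a 1.7-fold higher number from compound 3 to compound 4 (0.22 log units; within the scatter), and the two cores do not separate on this change: the same change on two cores in this assay, a 2.4-fold higher number (0.37 log units; beyond the scatter) from compound 1 to compound 2 and a 1.7-fold higher number (0.22 log units; within the scatter) from compound 3 to compound 4, 1.4-fold (0.15 log units) apart, within the scatter of two such steps. For the compounds shown here, on these two cores, then, the change carries over with no difference that can be told from scatter, although only the step on the core of compound 1 lies beyond the scatter by itself. Two pairs in one assay do not show that the step would hold on any further core.

Open, as far as these compounds go, is how an amine, a carboxylic acid or a fluorine would read at this same aromatic carbon. Also open, from the compounds shown here alone, is whether such a group would behave alike on both cores.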